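Hydroxy to Bromine on the Styryl Ring

This account rests on a few compounds, and the source may have more. Where it says the series, first, only, none or still open, it means among the compounds named here.

Compound 3 `O=C(/C(=C\c1ccccc1O)Sc1ccccc1Br)c1ccc(Br)cc1` sits at the weak end of a small set. In a functional assay on DU-145 cells (Homo sapiens) for inhibition, read by trypan blue exclusion, with a stated time of 96 h (on this read-out lower numbers stand for stronger inhibition of growth and higher numbers for weaker inhibition of growth), compound 3 gives 50000 nM. Compound 2 `O=C(/C(=C\c1ccc(O)cc1O)Sc1ccccc1Br)c1ccc(Br)cc1` carries one more hydroxy group on the same ring, and in this assay compound 2 gives 50000 nM. The step of no change at the digits printed from compound 2 to compound 3 (within the scatter) shows that taking away that hydroxy left the read-out where it was. For the measured compounds named here, compound 1 `O=C(/C(=C\c1ccc(O)cc1)SCc1ccc(Cl)cc1)c1ccc(Br)cc1` differs from both in two places, on the styryl ring and on the sulfur substituent, and in this assay compound 1 gives 10000 nM, the lowest of the three numbers, with no single-change step to connect it to compound 3.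

Compound 4 `O=C(/C(=C\c1ccc(Br)cc1)Sc1ccccc1Br)c1ccc(Br)cc1` is the next compound, not yet measured. It differs from compound 3 in one place: 4-bromophenyl in place of 2-hydroxyphenyl on a double-bonded chain carbon bound to a double-bonded chain carbon. Going by the values given here, the only measured step on that ring, from compound 2 to compound 3, was a removal of hydroxy and produced no change beyond the scatter; no measured step introduces bromine there. The expectation is therefore a step of a 1.7-fold lower number from compound 3 to compound 4 (0.22 log units; within the scatter) that stays near the scatter, with a slight lean toward a lower number because compound 1, which also lacks a hydroxy at that position, gives 10000 nM. Compound 4 is estimated at 30000 nM, within 8000 nM to 100000 nM.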

Compound 4, concentration for 50% growth inhibition: 1000 nM
For compound 4 the middle estimate is 30-fold (1.48 log units) above the measured one; measured number below the stated range.
By their numbers in this assay, from the lowest: compound 4; then compound 1; then compounds 2 and 3 (each within the scatter of the next).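

In this assay, the step of 4-bromophenyl in place of 2-hydroxyphenyl gives a 50-fold lower number from compound 3 to compound 4 (1.70 log units; beyond the scatter), and the step of 4-bromophenyl in place of 2,4-dihydroxyphenyl gives a 50-fold lower number from compound 2 to compound 4 (1.70 log units; beyond the scatter). The earlier compounds shown here held only the loss of one hydroxy on this ring, no change at the digits printed from compound 2 to compound 3 (within the scatter), so they gave no sign that the group on this double-bonded chain carbon could move the read-out so far. The new steps show that it can: replacing the hydroxy-bearing ring with the bromine-bearing one takes the read-out well beyond the scatter from both hydroxy compounds, though nothing given here accounts for the size of that drop.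

Each of the two large steps removes all hydroxy from the ring and brings in bromine at once, so the compounds shown do not separate the part played by the departing hydroxy from that of the entering bromine. A plain phenyl at this place would divide the two, and a chlorine or a methoxy group in place of the bromine would test whether the bromine itself is needed.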